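The source may hold more compounds than are shown below. What is called first, only, known or untested is meant among the compounds shown, and "the series" means these compounds.

Compound 1 (`Cc1c(COCCCCO)[nH]c2ccccc2c1=O`) has "not determined" (no result reported) in an in vitro ADME assay on microsomes from liver (Mus musculus) for metabolic stability, tested at 0.2 uM; a higher number here means faster removal of the compound, a lower number slower removal. In this assay compound 2 (`CCCCOc1cccc(OCc2[nH]c3ccccc3c(=O)c2C)c1`) gives > 1000 mL/min/kg, which is a limit of the assay and not a number. Compound 3 (`COC(C)(C)CCOc1cccc(OCc2[nH]c3ccccc3c(=O)c2C)c1`) differs from it by 1-methoxy-1-methylethyl in place of ethyl on a saturated chain carbon, two bonds along the chain from an oxygen on an aromatic ring, which also reads as butoxy to 3-methoxy-3-methylbutoxy. For the measured compounds named here, no measured step covers this change, so the expectation rests only on compound 2 sitting at the limit > 1000 mL/min/kg, from which a measurable result can only lie lower. The estimated step of an at least 2.0-fold lower number from compound 2 to compound 3 (0.30 log units; that floor lies within the scatter) is downward, of uncertain size. For compound 3 the expected clearance is 500 mL/min/kg, with an estimated range of 150 mL/min/kg to 1200 mL/min/kg.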

Compound 3, clearance: > 1000 mL/min/kg
Compound 3: only a limit was reported; the forecaster's own chance of this, stated with the estimate: 35%; at least 2.0-fold (0.30 log units) between middle value and limit.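

No step from compound 2 to compound 3 can be read in this assay, because both results are limits and not numbers: the limit of > 1000 mL/min/kg in this assay, at which 2 of the 3 values shown sit.

The compounds shown leave open the actual clearance of each and whether 3-methoxy-3-methylbutoxy in place of butoxy changes it.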